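Swapping nitro for methoxy on a weak antiproliferative scaffold

A few compounds are considered here, and "the series" means these few. Any claim that something is new, unique, unknown or untested is made for them only; others in the source may bear on it.

Measured compounds:
compound 1, `Cc1cnc(Nc2ccc([N+](=O)[O-])cc2)nc1Nc1nc2ccccc2s1`, 22500 nM
compound 2, `Cc1ccc2nc(Nc3nc(Nc4ccc(S(N)(=O)=O)cc4)ncc3C)sc2c1`, 9080 nM
compound 3, `COc1ccc2nc(Nc3ccnc(Nc4ccc(S(C)(=O)=O)cc4)n3)sc2c1`, 32700 nM

The three compounds were tested in a functional assay on MDA-MB-231 cells (Homo sapiens) for antiproliferative activity, read by MTT assay, with a stated time of 48 h; a lower number here means a stronger inhibitor, a higher number a weaker inhibitor. Compound 1 gives 22500 nM, the second highest of the three numbers. Compound 3 sits nearest, and the gap between them lies within the scatter, so no order can be read from it. Compound 2 shows the lowest number, and its distance from compound 1 lies beyond the scatter.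

Compound 4, `COc1ccc(Nc2ncc(C)c(Nc3nc4ccccc4s3)n2)cc1`, has not yet been measured in this assay. It differs from compound 1 in one place: methoxy in place of nitro on an aromatic carbon.

Going by the values given here, no step between measured compounds isolates this change, so the expectation rests on compound 1 alone. A step of modest size, tending toward a lower number or none beyond the scatter, is expected: a 1.3-fold lower number from compound 1 to compound 4 (0.10 log units; within the scatter). Compound 4 is estimated at 18000 nM, with a range from 6000 nM to 54000 nM.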

Compound 4, half-maximal inhibitory concentration: > 50000 nM
Compound 4 was reported as a limit; the forecaster's own chance of this, stated with the estimate: 10%; middle value at least 2.7-fold (0.44 log units) from the limit.
By their numbers in this assay, from the lowest: compound 2; then compounds 1 and 3 (each within the scatter of the next). At a limit, above all of these: compound 4.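

In this assay, methoxy in place of nitro on an aromatic carbon para to a large group gives an at least 2.2-fold higher number from compound 1 to compound 4 (0.34 log units; beyond the scatter). Going by these compounds alone, this is the first view of this position, and it shows that the group held there matters to this read-out, with nitro the better of the two. Compound 4 stands only as a limit, so the full size of the step cannot be read: the limit of > 50000 nM in this assay, at which 1 of the 4 values shown sits.

On these data alone, whether an amine or a carboxylic acid on this carbon would give a lower number than nitro stays open.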